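Methylcarbamoyl in place of the dimethylpyrazole: outlook for compound 3

This account rests on a few compounds, and the source may have more. Where it says the series, first, only, none or still open, it means among the compounds named here.

Of the compounds shown here, two have numbers so far. Compound 1 `Cc1n[nH]c(C)c1-c1cncc(-c2ccc(C(N)=O)c(OC(C)C)c2)c1` gives 33 nM in an assay on cells for inhibition of MAP kinase-interacting serine/threonine-protein kinase 1 (Homo sapiens), read by mobility shift assay, with stated times of 10 min and 60 min, in the presence of a further agent that is not named here; on this read-out lower numbers stand for stronger inhibition and higher numbers for weaker inhibition. Among the compounds with values here, compound 2 `Cc1c(-c2cncc(-c3ccc(C(N)=O)c(OC(C)C)c3)c2)cnn1C` gives 60 nM in this assay, the higher of the two numbers, with compound 1 as its only neighbour. Within the data shown here, the single step between measured compounds is a 1.8-fold higher number from compound 1 to compound 2 (0.26 log units; within the scatter), so the two are read as equivalent rather than ordered.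

Compound 3 `CNC(=O)c1cncc(-c2ccc(C(N)=O)c(OC(C)C)c2)c1` is not yet measured. It differs from compound 2 in one place: methylcarbamoyl in place of 1,5-dimethyl-1H-pyrazol-4-yl on an aromatic carbon. Among the measured compounds shown here, no measured step covers a change of this kind. For the measured compounds named here, the one step in hand moves methyl groups within the same five-membered ring and therefore says little about exchanging that ring for a group without a ring. The expectation for compound 3 is accordingly broad: a loss beyond the scatter is taken as the working assumption, with the expected step of a 3.0-fold higher number from compound 2 to compound 3 (0.48 log units; beyond the scatter). Compound 3 is estimated at 180 nM in this assay, with a range from 40 nM to 800 nM.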

Compound 3, half-maximal inhibitory concentration: 1900 nM
Compound 3: middle estimate off by 11-fold (1.02 log units), on the low side, outside the stated range (above it).
By their numbers in this assay, from the lowest: compounds 1 and 2 (each within the scatter of the next); then compound 3.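

In this assay this position, two atoms from the ring nitrogen, proves far less tolerant of a change of group than the earlier pair suggested: methylcarbamoyl in place of 1,5-dimethyl-1H-pyrazol-4-yl gives a large loss (a 32-fold higher number from compound 2 to compound 3 (1.50 log units; beyond the scatter)), and methylcarbamoyl in place of 3,5-dimethyl-1H-pyrazol-4-yl gives another (a 58-fold higher number from compound 1 to compound 3 (1.76 log units; beyond the scatter)). Both dimethylpyrazole isomers therefore stand well apart from the methylcarbamoyl compound, so the large step does not depend on which of the two is the starting point. No independent measurement is at hand that accounts for the size of this loss.

The change removes the five-membered aromatic ring, lowers the heavy-atom count and brings in a hydrogen-bond donor all at once, so the compounds shown leave open which of these differences goes with the loss. A phenyl ring or an unsubstituted pyrazole at this position, or a longer chain on the amide nitrogen, would help to separate the contribution of the ring from that of the amide.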